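Hydrazone series on a shared core: adding a second chloro

The compounds below may be only part of what the source reports. "The series", "measured", "known", "first", "only" and "open" are said of these compounds alone.

Measured compounds in a functional assay on MCF7 cells (Homo sapiens) for cytotoxicity, read by MTT assay, with a stated time of 48 h; a higher number here means a weaker inhibitor, a lower number a stronger inhibitor:
compound 1 `O=C(CSc1nnc(-c2ccncc2)o1)N/N=C/c1ccc(F)cc1` gives 13500 nM
compound 2 `Cc1ccc(/C=N/NC(=O)CSc2nnc(-c3ccncc3)o2)cc1` gives 14700 nM
compound 3 `O=C(CSc1nnc(-c2ccncc2)o1)N/N=C/c1cc(Cl)ccc1O` gives 5830 nM

Compound 3 stands lowest of the three numbers. Its lead over compound 1 is a 2.3-fold lower number from compound 1 to compound 3 (0.36 log units; beyond the scatter) and over compound 2 is a 2.5-fold lower number from compound 2 to compound 3 (0.40 log units; beyond the scatter); both are modest, both beyond the scatter. Compounds 1 and 2 sit within the scatter of each other, as a 1.1-fold higher number from compound 1 to compound 2 (0.04 log units; within the scatter) shows, so no order between them is claimed.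

Compound 4 `O=C(CSc1nnc(-c2ccncc2)o1)N/N=C/c1cc(Cl)cc(Cl)c1O` differs from compound 3 by chloro in place of hydrogen on an aromatic carbon, placed on an aromatic carbon of the six-membered ring of carbon only, ortho to the hydroxy group and meta to the existing chloro group. Going by the values given here, no measured step in this assay adds a substituent to that ring while keeping the rest fixed; the steps from compound 1 and compound 2 to compound 3 exchange the whole aryl group, so they bear only loosely. The read-across therefore rests on compound 3 alone, and a step within the scatter, or a small lowering at most, is expected. Compound 4 is expected to give 4200 nM in this assay, with a range of 1500 nM to 11000 nM, corresponding to an estimated step of a 1.4-fold lower number from compound 3 to compound 4 (0.14 log units; within the scatter).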

Compound 4, half-maximal inhibitory concentration: 5920 nM
Compound 4: the middle estimate sits 1.4-fold (0.15 log units) below what was measured; low and high end bracket the measured number.
By their numbers in this assay, from the lowest: compounds 3 and 4 (each within the scatter of the next); then compounds 1 and 2 (each within the scatter of the next).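

In this assay, chloro in place of hydrogen on this aromatic carbon, ortho to a hydroxy group and meta to a chloro group, gives a 1.0-fold higher number from compound 3 to compound 4 (0.01 log units; within the scatter), so compound 3 and compound 4 cannot be told apart. The 3,5-dichloro-2-hydroxyphenyl group keeps a modest margin over the two simpler aryl groups, with a 2.5-fold lower number from compound 2 to compound 4 (0.39 log units; beyond the scatter) and a 2.3-fold lower number from compound 1 to compound 4 (0.36 log units; beyond the scatter), and these margins match those already held by the 5-chloro-2-hydroxyphenyl group. No evidence is available to explain this result.

Going by these compounds, whether a methoxy group, an amine or a longer chain on this carbon would read like chloro remains open. Also open, on these data alone, is whether the hydroxy group or the first chloro carries the margin over compound 1 and compound 2.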